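Swapping one methyl-bearing ring for its isomer

The source may report more compounds than this note shows. Statements on the series, on what has been measured and on what is new or still open speak of the compounds shown alone.

Measured so far in a physicochemical assay for lipophilicity, measured as octanol-water partition, at pH 7.4; a lower number here means a more polar compound, a higher number a more lipophilic compound:
Compound 1 `Cc1ccc(Cn2c(=O)[nH]c3c(N)nc(C(F)(F)F)cc32)nn1`: 1.1
Compound 2 `Cc1cc(Cn2c(=O)[nH]c3c(N)nc(C(F)(F)F)cc32)no1`: 2.1

Of these two, compound 2 holds the higher number, at 2.1. Compound 3 `Cc1nc(Cn2c(=O)[nH]c3c(N)nc(C(F)(F)F)cc32)co1` has not been measured yet. It has the same atoms as compound 2, joined differently: 2-methyl-1,3-oxazol-4-yl in place of 5-methyl-1,2-oxazol-3-yl on a saturated chain carbon bound to an aromatic nitrogen. Within the data shown here, only one measured step bears on this change: a number 1.00 log units higher from compound 1 to compound 2 (beyond the scatter). That step shows that exchanging the group at this place can matter, but it involved a different pair of groups, so it is only a loose guide. In this assay, the expected result is a number 0.20 log units lower from compound 2 to compound 3 (within the scatter), a shift not expected to exceed the scatter. Compound 3 is estimated at 1.9, within an expected range from 1.5 to 2.3.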

Compound 3, distribution coefficient: 1.7
Beside the measured number, compound 3's estimate is 0.20 log units above it; the measured number falls inside the stated range.
By their numbers in this assay, from the lowest: compound 1; then compound 3; then compound 2.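

Merely rearranging the ring atoms moves the number in this assay beyond the scatter: 2-methyl-1,3-oxazol-4-yl in place of 5-methyl-1,2-oxazol-3-yl gives a number 0.40 log units lower from compound 2 to compound 3 (beyond the scatter) even though the counted atoms, donors and acceptors stay identical. Replacing 6-methylpyridazin-3-yl with the same group gives a number 0.60 log units higher from compound 1 to compound 3 (beyond the scatter) so both five-membered rings stand above compound 1, with compound 3 in the middle. Nothing available explains why the two isomers differ. Also open, as far as these compounds go, is whether an amine or a carboxylic acid in place of the methyl on these rings would keep the same order.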